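Swapping Chloro for Nitro at the Assay Limit

The compounds below may be only part of what the source reports. "The series", "measured", "known", "first", "only" and "open" are said of these compounds alone.

In a functional assay on the whole organism for activation, with Mus musculus as the target, with a stated time of 60 min (a higher number here means that more compound is needed for the effect, a lower number that less compound is needed), compound 1 (`O=C1NC(=O)N(/N=C/c2ccc(-c3ccc(Cl)cc3)o2)C1O`) gives > 1000 mg/kg, which is a limit and not a number. Compound 2 (`CC(=O)Nc1ccc(-c2ccc(/C=N/N3C(=O)NC(=O)C3O)o2)cc1`) gives > 1000 mg/kg, also a limit. Compound 3 (`O=C1CN(/N=C/c2ccc(-c3cccc(C(F)(F)F)c3)o2)C(=O)N1`) gives 647 mg/kg and differs from both in more than one place. Compound 4 (`O=C1NC(=O)N(/N=C/c2ccc(-c3ccc([N+](=O)[O-])cc3)o2)C1O`) carries nitro in place of chloro on an aromatic carbon of compound 1: nitro in place of chloro on an aromatic carbon. Among the compounds with values here, the one measured step bearing on this also replaces chloro: a step that the two limits leave unreadable from compound 1 to compound 2. Its size cannot be read, so it suggests no direction. The expectation therefore rests on (the limit of > 1000 mg/kg in this assay, at which 2 of the 3 values shown sit). The estimated step is a number no higher from compound 1 to compound 4 (the limit leaves the size open), with no direction favoured. For compound 4 the estimate is 1000 mg/kg, with an expected range of 300 mg/kg to 2500 mg/kg.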

Compound 4, dose for half-maximal effect: > 1000 mg/kg
Compound 4 was reported as a limit (the forecaster's own chance of this, stated with the estimate: 60%); the middle value sits exactly at the limit.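

Compound 4, like compound 1 and compound 2, is reported only as a limit, and no step among these three can be read. The compounds shown leave open whether chloro, acetamido or nitro on that aromatic carbon changes the dose needed at all.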